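Urotensin-2 receptor binding: ester aryl group to anilino group

The compounds below may be only part of what the source reports. "The series", "measured", "known", "first", "only" and "open" are said of these compounds alone.

Measured so far, in an assay on NIH3T3 cells with Urotensin-2 receptor (Homo sapiens) as the target; on this read-out lower numbers stand for an effect already at smaller amounts and higher numbers for an effect only at larger amounts of compound:
compound 1 `Cc1ccccc1C(=O)OC(CCN(C)C)c1ccc(Cl)cc1` gives 1700 nM;
compound 2 `Cc1ccc(C(=O)OC(CCN(C)C)c2ccc(Cl)cc2)cc1` gives 2750 nM.

Among the measured compounds shown here, compound 2 stands with the highest of the two numbers in this assay, with compound 1 nearest; the only step measured so far is a 1.6-fold higher number from compound 1 to compound 2 (0.21 log units; within the scatter), and it stays within the scatter.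

The next compound, compound 3 `Cc1ccccc1NC(=O)OC(CCN(C)C)c1ccc(Cl)cc1`, differs from compound 2 in that ((2-methylphenyl)amino in place of 4-methylphenyl on a carbonyl carbon). For the measured compounds named here, the measured step from compound 1 to compound 2 bears on the position of the methyl group only and was within the scatter; for the nitrogen that enters on the carbonyl carbon no step has been measured. On that basis no shift beyond the scatter is expected in this assay, and the estimated step is a 1.5-fold lower number from compound 2 to compound 3 (0.18 log units; within the scatter). The expected value for compound 3 is 1800 nM, with a range from 500 nM to 6500 nM.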

Compound 3, half-maximal effective concentration: 3890 nM
Beside the measured number, compound 3's estimate is 2.2-fold (0.33 log units) below it, within the range that was stated.
By their numbers in this assay, from the lowest: compounds 1, 2 and 3 (each within the scatter of the next, the first and the last beyond it).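

In this assay, among the compounds shown here, (2-methylphenyl)amino in place of 2-methylphenyl on the carbonyl carbon gives a 2.3-fold higher number from compound 1 to compound 3 (0.36 log units; beyond the scatter), the first step to pass the scatter, though only modestly, and it keeps the methylphenyl group while adding a nitrogen with its hydrogen-bond donor. The comparison with 4-methylphenyl gives a 1.4-fold higher number from compound 2 to compound 3 (0.15 log units; within the scatter), which stays within the scatter and so does not separate the two groups on its own. Nothing available explains the modest step.

Still open, going by these compounds, is whether the step follows the amide hydrogen or the nitrogen itself, which a (methyl)(2-methylphenyl)amino group on the same carbonyl carbon would help to test. Also open, on these data alone, is how (4-methylphenyl)amino or a benzylamino group would read at this position.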